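Amide pyrrolidine nitrogen substituent: isopropyl to cyclopropyl

This account rests on a few compounds, and the source may have more. Where it says the series, first, only, none or still open, it means among the compounds named here.

Among the measured compounds shown here, compound 2 `CC(C)N1CC[C@H](NC(=O)c2cc(-c3ccc(NS(=O)(=O)c4cccc(Cl)c4Cl)cc3)nc3[nH]ncc23)C1` carries the only number in an assay for inhibition of serine/threonine-protein kinase Sgk1 (Homo sapiens), with stated times of 30 min and 60 min, in the presence of a further agent that is not named here; a higher number here means a weaker inhibitor, a lower number a stronger inhibitor: compound 2 gives 4 nM. Compound 1 `CN1CCC(NC(=O)c2cc(-c3ccc(NS(=O)(=O)c4cccc(Cl)c4Cl)cc3)nc3[nH]ncc23)C1` has in this assay only a limit, < 1 nM, not a number. The step of an at least 4.0-fold higher number from compound 1 to compound 2 (0.60 log units; beyond the scatter) is therefore known only as a lower bound, because the limit of < 1 nM in this assay, at which 1 of the 2 values shown sits, sets the value of compound 1. Compound 3 `O=C(NC1CCN(C2CC2)C1)c1cc(-c2ccc(NS(=O)(=O)c3cccc(Cl)c3Cl)cc2)nc2[nH]ncc12` is not yet measured in this assay; its change from compound 2 is 1-cyclopropylpyrrolidin-3-yl in place of 1-isopropylpyrrolidin-3-yl on an amide-type nitrogen. For the measured compounds named here, the single measured step at this place, from 1-methylpyrrolidin-3-yl to 1-isopropylpyrrolidin-3-yl, gave a higher number; no measured step involves 1-cyclopropylpyrrolidin-3-yl, so the direction for compound 3 rests on that one step alone and is uncertain. The expectation is that compound 3 stays close to compound 2, with at most a modest lower number, estimated as a 1.6-fold lower number from compound 2 to compound 3 (0.20 log units; within the scatter). Compound 3 is thus expected at 2.5 nM in this assay, within 1 nM to 8 nM, with some chance that only a limit is reported.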

Compound 3, half-maximal inhibitory concentration: 6 nM
The estimate for compound 3 lay 2.4-fold (0.38 log units) below the measured number, within the range that was stated.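

In this assay, replacing 1-isopropylpyrrolidin-3-yl with 1-cyclopropylpyrrolidin-3-yl on the amide-type nitrogen gives a 1.5-fold higher number from compound 2 to compound 3 (0.18 log units; within the scatter), so compound 2 and compound 3 cannot be told apart, and a three-membered ring of carbon only is accepted at this position with the heavy-atom count unchanged. Cyclopropyl in place of methyl gives an at least 6.0-fold higher number from compound 1 to compound 3 (0.77 log units; beyond the scatter), which points the same way as an at least 4.0-fold higher number from compound 1 to compound 2 (0.60 log units; beyond the scatter), so the methyl group of compound 1 remains the only substituent shown with a clear edge, and neither of the other two compounds goes against this. Compound 1 has a limit rather than a number, and both steps from it are lower bounds, with their true size unknown, because of this: the limit of < 1 nM in this assay, at which 1 of the 3 values shown sits.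

The drawn structures leave open whether the defined stereocentre of compound 2, absent from the drawing of compound 3, affects this comparison. Also open, as far as these compounds go, is how this assay would read with a free amine hydrogen, an ethyl group or a cyclobutyl group on the pyrrolidine nitrogen, and whether the trend from methyl would hold across those groups.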